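Thiazolidine amides: aryl versus alkyl at the ring carbon

A few compounds are considered here, and "the series" means these few. Any claim that something is new, unique, unknown or untested is made for them only; others in the source may bear on it.

Measured so far:
compound 1, `CCCCCCCCCCCCCCCCCCNC(=O)[C@H]1CSC(CCCCCCCCCCCC)N1`, 11900 nM;
compound 2, `CCCCCCCCCCCCCCCCCCNC(=O)[C@H]1CSC(c2c[nH]c3ccccc23)N1`, 2100 nM.

Both values come from a functional assay on LNCaP cells (Prostate gland, Homo sapiens) for antiproliferative activity, read by sulforhodamine B assay; a lower number here means a stronger inhibitor, a higher number a weaker inhibitor. Compound 2 gives the lowest number of the two; its nearest neighbour is compound 1, and the step of a 5.7-fold lower number from compound 1 to compound 2 (0.75 log units; beyond the scatter) is the only one shown, placing an aromatic group on the saturated ring carbon in place of a long chain.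

Compound 3, `CCCCCCCCCCCCCCCCCCNC(=O)[C@H]1CSC(c2cccnc2)N1`, has not been measured. It differs from compound 2 by pyridin-3-yl in place of 1H-indol-3-yl on a saturated ring carbon. Going by the values given here, the only step that bears on this change is a 5.7-fold lower number from compound 1 to compound 2 (0.75 log units; beyond the scatter), which concerns the same ring carbon but swaps a chain for an aromatic group; here one aromatic group replaces another, so that step gives only a loose guide. A smaller aromatic group with fewer heavy atoms might give back part of the gain, and compound 3 is therefore expected to sit between the two measured compounds, with a step of a 2.1-fold higher number from compound 2 to compound 3 (0.33 log units; beyond the scatter).

Estimate for compound 3: in this assay it is expected to show 4500 nM, likely between 1500 nM and 13000 nM.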

Compound 3, half-maximal inhibitory concentration: 3600 nM
For compound 3 the middle estimate is 1.3-fold (0.10 log units) above the measured one; low and high end bracket the measured number.
By their numbers in this assay, from the lowest: compounds 2 and 3 (each within the scatter of the next); then compound 1.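

In this assay the two aromatic groups at this saturated ring carbon are not separated: a 1.7-fold higher number from compound 2 to compound 3 (0.23 log units; within the scatter) stays within the scatter, even though pyridin-3-yl brings a single six-membered ring in place of the two rings of 1H-indol-3-yl and has no hydrogen-bond donor. The gain over the dodecyl group is therefore not confined to 1H-indol-3-yl, since a 3.3-fold lower number from compound 1 to compound 3 (0.52 log units; beyond the scatter) also lies beyond the scatter, and among the compounds shown none goes against this. No measured evidence gives a reason for either step.

Still open, going by these compounds, is whether a plain phenyl ring at this carbon, or one bearing an amine or a carboxylic acid, would fall in the same range. The compounds shown also leave open what a shorter chain on the amide nitrogen would do.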